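This account rests on a few compounds, and the source may have more. Where it says the series, first, only, none or still open, it means among the compounds named here.

In a functional assay on MDA-MB-436 cells (Homo sapiens) for antiproliferative activity, read by MTT assay, with a stated time of 24 h (a lower number here means a stronger inhibitor, a higher number a weaker inhibitor), the measured compounds read as follows:

Compound 1 `O=C(O)CC(NC(=O)c1cccc(Br)c1)c1ccccc1` gives > 100000 nM as a limit
Compound 2 `O=C(O)CC(NC(=O)c1ccc(Cl)cc1Cl)c1ccccc1` gives 78200 nM as a measured number
Compound 3 `O=C(O)CC(NS(=O)(=O)c1ccccc1)c1ccccc1` gives > 100000 nM as a limit

Compound 3 stands at > 100000 nM and this is a limit of the assay, not a number. The set as a whole gathers at the limit of > 100000 nM in this assay, at which 2 of the 3 values shown sit, and only compound 2 gives a true number.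

Compound 4 `O=C(O)CC(NS(=O)(=O)c1ccccc1Br)c1ccccc1` differs from compound 3 in one place: bromo in place of hydrogen on an aromatic carbon and the change is bromo in place of hydrogen on an aromatic carbon, ortho to a large group. In short, phenyl becomes 2-bromophenyl.

For the measured compounds named here, no measured pair in this assay shows what such a change does, so any expectation here is loose. Compound 1 also carries a bromo group, and its > 100000 nM is a limit. Going by the values given here, compound 2 reaches 78200 nM in the same assay, so even the one number on hand shows only weak activity. The estimated step of an at least 1.0-fold lower number from compound 3 to compound 4 (0.02 log units; that floor lies within the scatter) is expected to stay within the usual scatter, with no clear direction. For compound 4 the estimated value is 95000 nM with an expected range from 45000 nM to 200000 nM and a reading that gives only a limit would be no surprise.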

Compound 4, half-maximal inhibitory concentration: > 100000 nM
Compound 4: a limit, no number; the forecaster's own chance of this, stated with the estimate: 55%; middle value at least 1.0-fold (0.02 log units) from the limit.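

For the compounds shown here, compound 3 and compound 4 each give only a limit of the assay rather than a number, so no step between them can be read, because both sit at that shared limit: the limit of > 100000 nM in this assay, at which 3 of the 4 values shown sit. The compounds shown leave open whether 2-bromophenyl in place of phenyl shifts activity in either direction in this assay.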